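Vero cytotoxicity notes: three measured analogues, one pending

The source may report more compounds than this note shows. Statements on the series, on what has been measured and on what is new or still open speak of the compounds shown alone.

Measured so far, in an ADME assay on Vero cells (Chlorocebus sabaeus) for cytotoxicity, read by neutral red uptake, tested at 12.3 ug/mL; on this read-out higher numbers stand for a weaker effect at the one concentration tested and lower numbers for a stronger effect:
- compound 1 `O=C1CSC(c2cccc(Cl)c2)N1CCN1CCCCC1` gives 100%
- compound 2 `COc1ccccc1C1SCC(=O)N1CCN1CCCCC1` gives 100%
- compound 3 `O=C1CSC(c2ccccc2[N+](=O)[O-])N1CCN1CCCCC1` gives 100%

Compound 1 stands level with compounds 2 and 3 in this assay; its nearest neighbour is compound 2 and its furthest compound 3, and to each it shows no change within the scatter. Going by the values given here, the one step between measured compounds, no change at the digits printed from compound 2 to compound 3 (within the scatter), lies within the scatter.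

Compound 4 `O=C1CSC(c2cccc(F)c2)N1CCN1CCCCC1` differs from compound 1 by fluoro in place of chloro on an aromatic carbon. Among the compounds with values here, no measured step covers this change; the only guide is that every change so far, including the step from compound 2 to compound 3, left this assay unmoved. A step of no change at the digits printed from compound 1 to compound 4 (within the scatter) is therefore expected, none beyond the scatter. Compound 4 is estimated at 100%, with a range from 88% to 105%.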

Compound 4, a percentage reported as activity, at one concentration (the size of the read-out at that concentration, not a potency): 100%
Estimate against measurement, compound 4: no gap at the digits printed, within the range that was stated.
By their numbers in this assay, from the lowest: compounds 1, 2, 3 and 4 (each within the scatter of the next).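

In this assay there is no change at the digits printed from compound 1 to compound 4 (within the scatter) for fluoro in place of chloro, the first step read at this place, an aromatic carbon meta to a large group. The earlier step exchanged methoxy for nitro, so the unmoved read-out now also covers the exchange of one halogen for another. No measurement at hand bears on this result.

As far as these compounds go, whether an amine, a carboxylic acid or a longer chain at this place would move the read-out stays open. Any change to the shared core remains equally open.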